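This account rests on a few compounds, and the source may have more. Where it says the series, first, only, none or still open, it means among the compounds named here.

In a functional assay on DU-145 cells (Homo sapiens) for inhibition, read by trypan blue exclusion, with a stated time of 96 h (a lower number here means a stronger inhibitor of growth, a higher number a weaker inhibitor of growth), compound 1 `O=C(/C(=C\c1ccc(O)cc1)SCc1ccc(Cl)cc1)c1ccc(Br)cc1` gives 10000 nM. Among the measured compounds shown here, compound 3 `O=C(/C(=C\c1ccc(O)cc1)SCc1ccc(Cl)cc1)c1ccc(Cl)cc1` gives 10000 nM, level with it, and the two share the highest number of the three measured so far. Compound 2 `COc1ccc(/C=C(/SCc2ccc(Cl)cc2)C(=O)c2ccc(Br)cc2)cc1O` gives 1000 nM, the lowest of the three. Placing 3-hydroxy-4-methoxyphenyl where 4-hydroxyphenyl stood brings a 10-fold lower number from compound 1 to compound 2 (1.00 log units; beyond the scatter), but that change lies at a different place from the one followed here. Placing chloro where bromo stood on an aromatic carbon brings no change at the digits printed from compound 1 to compound 3 (within the scatter), and this is the only measured exchange of one halogen for another.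

Compound 4 `O=C(/C(=C\c1ccc(O)cc1)SCc1ccc(F)cc1)c1ccc(Br)cc1` has yet to be measured. It differs from compound 1 by fluoro in place of chloro on an aromatic carbon, which turns 4-chlorobenzyl into 4-fluorobenzyl, with the fluoro para to a large group. For the measured compounds named here, no measured step alters this chloro, so the evidence is indirect. With only the halogen exchange that gave no change at the digits printed from compound 1 to compound 3 (within the scatter) as a guide, no step beyond the scatter is expected in this assay. The expected outcome is no change at the digits printed from compound 1 to compound 4 (within the scatter). For compound 4 the estimated value is 10000 nM, with an expected range from 3000 nM to 25000 nM.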

Compound 4, concentration for 50% growth inhibition: 10000 nM
The estimate for compound 4 equals the measured number at the digits printed; low and high end bracket the measured number.
By their numbers in this assay, from the lowest: compound 2; then compounds 1, 3 and 4 (each within the scatter of the next).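

In this assay, among the compounds shown here, the 4-chlorobenzyl group itself is now exchanged for 4-fluorobenzyl, with no change at the digits printed from compound 1 to compound 4 (within the scatter), so this halogen is tested directly for the first time; the earlier halogen exchange concerned the bromo on the other aromatic ring, with no change at the digits printed from compound 1 to compound 3 (within the scatter). Across compounds 1, 3 and 4, swapping one halogen for another at either of these two places therefore leaves the growth-inhibition number level, while the only step beyond the scatter, a 10-fold lower number from compound 1 to compound 2 (1.00 log units; beyond the scatter), lies at a different place, on the hydroxyphenyl group. No measurement given here explains why chloro and fluoro read alike at this position.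

The compounds shown leave open whether this level reading holds when the halogen on the benzyl group gives way to hydrogen, a methoxy group, an amine or a carboxylic acid, or when the group is replaced by a longer chain. They also leave open whether the fluoro exchange would read the same on the 3-hydroxy-4-methoxyphenyl background of compound 2, which gives 1000 nM in this assay.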